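A few compounds are considered here, and "the series" means these few. Any claim that something is new, unique, unknown or untested is made for them only; others in the source may bear on it.

Measured so far in a functional assay on the whole organism (strain NMRI) with Mus musculus as the target, with a stated time of 0.5 h; on this read-out lower numbers stand for an effect already at smaller amounts and higher numbers for an effect only at larger amounts of compound:
compound 1, `COc1ccc(Cn2cc(CO/N=C/c3c(-c4ccccc4)nc4c(C)cccn34)nn2)cc1`, gives 40 mg/kg
compound 2, `COc1ccc(Cn2cc(CO/N=C/c3c(-c4ccc(C)cc4)nc4c(C)cccn34)nn2)cc1`, gives 40 mg/kg
compound 3, `Cc1ccc(-c2nc3ccc(Br)cn3c2/C=N/OCc2cn(Cc3ccc(C#N)cc3)nn2)cc1`, gives 40 mg/kg

Compound 2 and compound 1 differ in one place only: hydrogen in place of methyl on an aromatic carbon. Among the measured compounds shown here, the outcome of this step, no change at the digits printed from compound 2 to compound 1 (within the scatter), is the one direct reading of what that change does on this read-out. Compound 3 is built on another core; the difference between the two cores is not broken down here. The values of compound 3 and compound 2 lie within the usual scatter of each other, and the same holds for compound 3 and compound 1.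

Compound 4, `N#Cc1ccc(Cn2cc(CO/N=C/c3c(-c4ccccc4)nc4ccc(Br)cn34)nn2)cc1`, is not yet measured. It differs from compound 3 by hydrogen in place of methyl on an aromatic carbon, the same change as between compound 2 and compound 1, at the same place. Since the earlier step came out as no change at the digits printed from compound 2 to compound 1 (within the scatter), the expectation for compound 4 is a step of no change at the digits printed from compound 3 to compound 4 (within the scatter) in this assay. Compound 4 is thus estimated at 40 mg/kg, most likely between 20 mg/kg and 80 mg/kg.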

Compound 4, minimum effective dose: 20 mg/kg
Compound 4: the middle estimate sits 2.0-fold (0.30 log units) above what was measured; measured number inside the range.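

Removing the methyl group, so that 4-methylphenyl becomes phenyl, gives in this assay a 2.0-fold lower number from compound 3 to compound 4 (0.30 log units; within the scatter), and setting this beside the same change on the core of compound 1 shows no difference that stands clear of the scatter: the same change on two cores in this assay, no change at the digits printed (within the scatter) from compound 2 to compound 1 and a 2.0-fold lower number (0.30 log units; within the scatter) from compound 3 to compound 4, 2.0-fold (0.30 log units) apart, within the scatter of two such steps

On these two cores, then, the change carries over in the sense that neither step can be told apart from the ordinary noise of the measurement. Among the compounds shown here, this does not show that the methyl group is without effect on every core, and with only two pairs a small effect of the change, or a small difference between the cores, could stay hidden in the scatter.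

The compounds shown carry only methyl or hydrogen at this place, so what a chlorine atom, a methoxy group or an amine would do there remains open. On these data alone, compound 1 and compound 4 differ in more than one place, so what each of those differences does on its own also remains open.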